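Bromo for chloro across two chromenone cores

A few compounds are considered here, and "the series" means these few. Any claim that something is new, unique, unknown or untested is made for them only; others in the source may bear on it.

Measured so far in an assay on isolated protein (strain Sprague-Dawley) for inhibition of Amine oxidase [flavin-containing] B (Rattus norvegicus), read by spectrophotometry, with a stated time of 5 min; on this read-out higher numbers stand for weaker inhibition and lower numbers for stronger inhibition:
Compound 1 `CCOc1cc(=O)oc2cc(OCc3cccc(Cl)c3)ccc12` gives 115 nM.
Compound 2 `CCOc1cc(=O)oc2cc(OCc3cccc(Br)c3)ccc12` gives 126 nM.
Compound 3 `O=c1cc(CCl)c2ccc(OCc3cccc(Cl)c3)cc2o1` gives 43.7 nM.

Compound 1 and compound 2 differ in one place: bromo in place of chloro on an aromatic carbon. The step is a 1.1-fold higher number from compound 1 to compound 2 (0.04 log units; within the scatter). Compound 3 carries another core; it differs from compound 1 in one place, (chloromethyl in place of ethoxy on an aromatic carbon), and the step is a 2.6-fold lower number from compound 1 to compound 3 (0.42 log units; beyond the scatter), leaving compound 3 with the lowest number of the three.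

Compound 4 `O=c1cc(CCl)c2ccc(OCc3cccc(Br)c3)cc2o1` is not yet measured. It stands to compound 3 as compound 2 stands to compound 1: bromo in place of chloro on an aromatic carbon, at a place described in the same words, so the change is the same. Because the earlier step of a 1.1-fold higher number from compound 1 to compound 2 (0.04 log units; within the scatter) stayed within the scatter, for compound 4 a step of similar size is expected, a 1.1-fold higher number from compound 3 to compound 4 (0.04 log units; within the scatter). Compound 4 is therefore estimated at 48 nM, between 25 nM and 95 nM.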

Compound 4, half-maximal inhibitory concentration: 209 nM
The estimate for compound 4 lay 4.4-fold (0.64 log units) below the measured number; the whole stated range lies below it.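

On the core of compound 3, bromo in place of chloro gives a 4.8-fold higher number from compound 3 to compound 4 (0.68 log units; beyond the scatter), so in this assay this change does not carry over unchanged from the core of compound 1: the same change on two cores in this assay, a 1.1-fold higher number (0.04 log units; within the scatter) from compound 1 to compound 2 and a 4.8-fold higher number (0.68 log units; beyond the scatter) from compound 3 to compound 4, 4.4-fold (0.64 log units) apart, beyond the scatter of two such steps. With bromo in place, chloromethyl in place of ethoxy gives a 1.7-fold higher number from compound 2 to compound 4 (0.22 log units; within the scatter), so that step also depends on the group at the other place: the same change on two cores in this assay, a 2.6-fold lower number (0.42 log units; beyond the scatter) from compound 1 to compound 3 and a 1.7-fold higher number (0.22 log units; within the scatter) from compound 2 to compound 4, 4.4-fold (0.64 log units) apart, beyond the scatter of two such steps. These two comparisons are one gap seen from two sides, resting on four compounds; they show that the two changes do not add independently here, but not why, nor how bromo for chloro behaves on any further core.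

Still open, going by these compounds, is whether fluoro or iodo on the same aromatic carbon would follow the chloro or the bromo compounds. Also open, on these data alone, is whether an amine or a longer chain in place of chloromethyl would keep the same dependence.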